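Anilide aryl variation on the shared core

The compounds below may be only part of what the source reports. "The series", "measured", "known", "first", "only" and "open" are said of these compounds alone.

In a functional assay on MCF7 cells (Homo sapiens) for inhibition, read by MTT assay, with a stated time of 72 h (on this read-out higher numbers stand for weaker inhibition and lower numbers for stronger inhibition), compound 2 `O=C(Nc1cccc(Cl)c1)c1ccc(/N=N\c2c[nH]c3ccccc23)cc1` gives 82700 nM, and compound 1 `O=C(Nc1ccccc1)c1ccc(/N=N\c2c[nH]c3ccccc23)cc1` gives 147000 nM in this assay. Within the data shown here, these two numbers sit within the scatter of each other, the sole measured step being a 1.8-fold lower number from compound 1 to compound 2 (0.25 log units; within the scatter). Compound 3 `COc1ccccc1NC(=O)c1ccc(/N=N\c2c[nH]c3ccccc23)cc1` has not yet been measured; it differs from compound 2 by 2-methoxyphenyl in place of 3-chlorophenyl on an amide-type nitrogen. Among the measured compounds shown here, the only measured step that bears on this change is the chloro step, and it did not move the number beyond the scatter, so swapping the chlorinated anilide ring for another substituted anilide ring has no precedent here that points in either direction, and the methoxy group itself has none at all. The expected step in this assay is therefore a 1.3-fold higher number from compound 2 to compound 3 (0.12 log units; within the scatter), within the scatter, with no direction claimed. Compound 3 is estimated at 110000 nM, with a range from 35000 nM to 350000 nM.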

Compound 3, half-maximal inhibitory concentration: 86500 nM
The estimate for compound 3 lay 1.3-fold (0.10 log units) above the measured number; low and high end bracket the measured number.
By their numbers in this assay, from the lowest: compounds 2, 3 and 1 (each within the scatter of the next).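

In this assay, 2-methoxyphenyl in place of 3-chlorophenyl on the amide-type nitrogen gives a 1.0-fold higher number from compound 2 to compound 3 (0.02 log units; within the scatter), and adding a methoxy group to the bare anilide ring gives a 1.7-fold lower number from compound 1 to compound 3 (0.23 log units; within the scatter). With the methoxy step now alongside the chloro step, two different substituents at two different places on the anilide ring both stay within the scatter, so across compound 1, compound 2 and compound 3 this ring has not yet shown any change in the number that can be told from the scatter. No independent measurement bears on this result.

On these data alone, whether an amine or a carboxylic acid on the anilide ring, or a longer alkyl chain in place of the ring, would move the number beyond the scatter stays open. Also open, as far as these compounds go, is how chloro and methoxy would compare if each stood at the other's place on the ring.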